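Swapping the aryl group on a pyrazole-based antiproliferative

The source may report more compounds than this note shows. Statements on the series, on what has been measured and on what is new or still open speak of the compounds shown alone.

Of the compounds shown here, three have been measured so far in a functional assay on BJAB cells (Homo sapiens) for antiproliferative activity, with a stated time of 4 days; a higher number here means that more compound is needed for the effect, a lower number that less compound is needed. All three share the same core and differ only in the aromatic group attached to it. Compound 1 `COc1cccc(-c2c(C)nn(-c3nc(-c4ccc(Cl)c(Cl)c4)c(SC(C)C)s3)c2C(=O)O)c1` carries a 3-methoxyphenyl group and gives 14000 nM, the highest number of the three. Compound 2 `Cc1nn(-c2nc(-c3ccc(Cl)c(Cl)c3)c(SC(C)C)s2)c(C(=O)O)c1-c1cc(C#N)cc(C(F)(F)F)c1`, with a 3-cyano-5-(trifluoromethyl)phenyl group, gives 3600 nM, and compound 3 `Cc1ccc(-c2c(C)nn(-c3nc(-c4ccc(Cl)c(Cl)c4)c(SC(C)C)s3)c2C(=O)O)cc1`, with a 4-methylphenyl group, gives 3800 nM. The two changes away from compound 1 moved the number by similar amounts: a 3.9-fold lower number from compound 1 to compound 2 (0.59 log units; beyond the scatter) and a 3.7-fold lower number from compound 1 to compound 3 (0.57 log units; beyond the scatter). Between the other two, a 1.1-fold higher number from compound 2 to compound 3 (0.02 log units; within the scatter).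

The unmeasured compound 4 `Cc1cc(C#N)cc(-c2c(C)nn(-c3nc(-c4ccc(Cl)c(Cl)c4)c(SC(C)C)s3)c2C(=O)O)c1` takes a further step from compound 1: 3-cyano-5-methylphenyl in place of 3-methoxyphenyl on an aromatic carbon. The new group combines a nitrile, as in compound 2, with a methyl, as in compound 3, so both measured steps bear on it. Because a 3.9-fold lower number from compound 1 to compound 2 (0.59 log units; beyond the scatter) and a 3.7-fold lower number from compound 1 to compound 3 (0.57 log units; beyond the scatter) point the same way and are of nearly the same size, a step of comparable size and direction is expected for compound 4 in this assay , that is, a 3.5-fold lower number from compound 1 to compound 4 (0.54 log units; beyond the scatter). Compound 4 is therefore estimated at 4000 nM, with a likely range from 1500 nM to 10000 nM.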

Compound 4, half-maximal effective concentration: 4800 nM
Estimate against measurement, compound 4: 1.2-fold (0.08 log units) below, and the stated range covers the measured number.
By their numbers in this assay, from the lowest: compounds 2, 3 and 4 (each within the scatter of the next); then compound 1.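

In this assay, for the compounds shown here, the 3-cyano-5-methylphenyl group gives a 2.9-fold lower number from compound 1 to compound 4 (0.46 log units; beyond the scatter) and so joins the two other replacements, which makes 3-methoxyphenyl the one group of the four with a number set apart from the rest at this position on the shared core. The closest comparison is a 1.3-fold higher number from compound 2 to compound 4 (0.12 log units; within the scatter) where the nitrile stays and only methyl stands in place of trifluoromethyl on the aromatic ring, and at this level of resolution the two groups cannot be told apart; the same holds for a 1.3-fold higher number from compound 3 to compound 4 (0.10 log units; within the scatter) even though the two rings carry different groups in different places. Nothing here gives a measured property that would explain these numbers.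

From the compounds shown here alone, it remains open whether the nitrile or the methyl alone would be enough, or whether a plain phenyl ring with no added group would already fall with compounds 2, 3 and 4 rather than with compound 1. A 3-hydroxyphenyl or a 3-aminophenyl group would test whether the step from compound 1 is tied to the methoxy group itself.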